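The compounds below may be only part of what the source reports. "The series", "measured", "known", "first", "only" and "open" are said of these compounds alone.

Measured in a functional assay on HeLa cells (Homo sapiens) for antiproliferative activity, read by resazurin assay; a higher number here means a weaker inhibitor, a lower number a stronger inhibitor:
- Compound 1 `CCSC(=S)SCC(=O)c1ccc(OC)cc1OC`: 12600 nM
- Compound 2 `CCSC(=S)SCC(=O)c1ccc(OC)cc1`: 2510 nM

Of these two compounds, compound 2 holds the lower number, at 2510 nM, while compound 1 stands at 12600 nM. Compound 3 `COc1ccc(C(=O)CS)cc1` has not yet been measured. It differs from compound 2 as follows: a hydrogen atom in place of a group of 5 heavy atoms (3 carbon, 2 sulfur; no ring), on a sulfur. The group of 5 heavy atoms is thus lost, and the sulfur carries a hydrogen atom instead.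

For the measured compounds named here, only one measured step is available: a 5.0-fold lower number from compound 1 to compound 2 (0.70 log units; beyond the scatter). That step puts hydrogen in place of methoxy on an aromatic carbon, not on a sulfur, so it bears on this change only as a gauge of size. Going by the values given here, the data contain no step at the sulfur, and both measured compounds carry the group that compound 3 lacks. A step of similar, modest size is therefore expected in this assay, leaning tentatively toward a higher number, though the direction is uncertain. The expected shift is a 2.8-fold higher number from compound 2 to compound 3 (0.45 log units; beyond the scatter). For compound 3 the estimated value is 7000 nM, with an expected range from 1500 nM to 30000 nM.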

Compound 3, half-maximal inhibitory concentration: 20000 nM
Beside the measured number, compound 3's estimate is 2.9-fold (0.46 log units) below it; the measured number falls inside the stated range.
By their numbers in this assay, from the lowest: compound 2; then compounds 1 and 3 (each within the scatter of the next).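

In this assay, for the compounds shown here, the sulfur gives the first measured change at this position: with a hydrogen atom in place of the group of 5 heavy atoms (3 carbon, 2 sulfur; no ring), the step is an 8.0-fold higher number from compound 2 to compound 3 (0.90 log units; beyond the scatter). For this pair, the loss of the group makes the inhibitor weaker, settling a direction that the earlier step on an aromatic carbon could not show, and the core with only a hydrogen on the sulfur still gives a measurable number. Nothing available explains why this loss raises the number.

A single pair cannot show whether the whole group of 5 heavy atoms is needed or whether a smaller or different group on the same sulfur would serve as well. A methyl group, a longer chain or a chain ending in an amine or a carboxylic acid on that sulfur would help to separate these possibilities, and the compounds shown leave open whether the step would keep its size on a core carrying a second methoxy group.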